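Aryl swap at the ring carbon: pyridin-3-yl for 2-chlorophenyl

This account rests on a few compounds, and the source may have more. Where it says the series, first, only, none or still open, it means among the compounds named here.

Of the compounds shown here, three on a shared core have been tested in an assay on isolated protein for inhibition of DNA topoisomerase 1 (Homo sapiens), tested at 100 uM; a higher number here means a stronger effect of the compound at the concentration tested, a lower number a weaker effect. Compound 1 `Clc1ccc(-c2cc(-c3ccsc3)nc(-c3ccco3)c2)o1` gives 8.2%. Compound 2 `Clc1ccc(-c2cc(-c3ccsc3)nc(-c3ccccc3Cl)c2)o1` gives 0%. Compound 3 `Cc1ccc(-c2cc(-c3ccoc3)cc(-c3ccsc3)n2)cc1` gives 13.2%. On the numbers shown compound 2 stands at the bottom; compound 1 sits within the scatter of it, and only compound 3 lies beyond. Within the data shown here, the one measured step at the place in question is a number 8.2 percentage points lower from compound 1 to compound 2 (within the scatter).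

Compound 4 `Clc1ccc(-c2cc(-c3cccnc3)nc(-c3ccsc3)c2)o1` differs from compound 2 by pyridin-3-yl in place of 2-chlorophenyl on an aromatic carbon. The group that leaves is 2-chlorophenyl, the group that enters is pyridin-3-yl, and it sits on an aromatic carbon of a six-membered aromatic ring with one nitrogen, the same carbon at which compound 1 carries furan-2-yl. Among the measured compounds shown here, only the step from compound 1 to compound 2 bears on the present change, and that step stayed within the scatter, so a swap of the aryl group at this place has not yet moved this assay beyond the scatter. No step beyond the scatter is therefore expected for this assay; the expected step is a number 6 percentage points higher from compound 2 to compound 4 (within the scatter). Compound 4 is estimated at 6% in this assay, with a range from 0% to 18%.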

Compound 4, a percentage reported as inhibition, at one concentration (the size of the read-out at that concentration, not a potency): 0%
For compound 4 the middle estimate is 6 percentage points above the measured one; the range from low to high includes it.
By their numbers in this assay, from the lowest: compounds 2, 4, 1 and 3 (each within the scatter of the next, the first and the last beyond it).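

At the aromatic carbon next to the ring nitrogen, three aryl groups can now be compared on the shared core. In this assay the change to pyridin-3-yl from 2-chlorophenyl gives no change at the digits printed from compound 2 to compound 4 (within the scatter) and the change to pyridin-3-yl from furan-2-yl gives a number 8.2 percentage points lower from compound 1 to compound 4 (within the scatter) so neither a ring nitrogen in the entering six-membered ring nor the loss of the chlorine moves this read-out beyond the scatter among these three groups. No measurement is at hand that would explain this flat reading.

On these data alone, all three groups at this place are aromatic rings, so it stays open whether an amine, a carboxylic acid or a longer alkyl chain here would give a step beyond the scatter in this assay on this core. Compound 3 differs from compound 2 in more than one place, so the gap between them cannot be assigned to any one group, and the contribution of the 5-chlorofuran-2-yl and thiophen-3-yl groups remains unread.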